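Series notes: varying the group next to the ring sulfur

The source may report more compounds than this note shows. Statements on the series, on what has been measured and on what is new or still open speak of the compounds shown alone.

Compound 1 `CC(C)(C)Cc1c(-c2cccnc2)sc(N)c1C(=O)c1ccc(Cl)cc1`, compound 2 `CC(C)(C)Cc1c(-c2ccccn2)sc(N)c1C(=O)c1ccc(Cl)cc1` and compound 3 `COc1ccccc1-c1sc(N)c(C(=O)c2ccc(Cl)cc2)c1CC(C)(C)C` share one core and differ only in the aromatic group attached next to the ring sulfur. In an assay on CHO cells for displacement of a labelled ligand from adenosine receptor A1 (Homo sapiens), read by scintillation counting, tested at 10 uM (on this read-out higher numbers stand for more inhibition at the one concentration tested (going by the name of the read-out) and lower numbers for less inhibition), compound 1 gives 1%. Compound 2 gives 1% in this assay, and compound 3 gives 1%. Compound 3 thus stands level with compounds 1 and 2: the steps of no change at the digits printed from compound 1 to compound 3 (within the scatter) and no change at the digits printed from compound 2 to compound 3 (within the scatter) are flat, as is no change at the digits printed from compound 1 to compound 2 (within the scatter).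

Compound 4 `Cc1noc(C)c1-c1sc(N)c(C(=O)c2ccc(Cl)cc2)c1CC(C)(C)C` is the next member: 3,5-dimethyl-1,2-oxazol-4-yl in place of 2-methoxyphenyl on an aromatic carbon. The change is again a swap of the aromatic group on an aromatic carbon, so the three measured steps bear on it directly, and each of them stayed within the scatter. Among the compounds with values here, nothing among the measured compounds points to a step in either direction in this assay. Compound 4 is therefore expected to sit at the same level, with an estimated a number 1 percentage points higher from compound 3 to compound 4 (within the scatter) of no size beyond the scatter. The estimate for compound 4 in this assay is 2%, with a range from -8% to 12%.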

Compound 4, a percentage reported as inhibition, at one concentration (the size of the read-out at that concentration, not a potency): 1%
Compound 4: middle estimate off by 1 percentage points, on the high side, and the stated range covers the measured number.
By their numbers in this assay, from the lowest: compounds 1, 2, 3 and 4 (each within the scatter of the next).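

The series now includes a five-membered aromatic ring with 2 hetero atoms at this position, not only six-membered rings, and the level holds: in this assay the swap to 3,5-dimethyl-1,2-oxazol-4-yl gives no change at the digits printed from compound 3 to compound 4 (within the scatter) and no change at the digits printed from compound 2 to compound 4 (within the scatter) and also no change at the digits printed from compound 1 to compound 4 (within the scatter). Across these compounds, then, neither the ring size nor the hetero atoms of the aromatic group at this position separate one compound from another in this read-out. No available measurement accounts for this flat result.

Still open, going by these compounds, is whether a non-aromatic group at this position, such as an aminomethyl group or a carboxylic acid, would depart from this level. Also open, on these data alone, is whether a change elsewhere on the shared core, such as a longer chain in place of the neopentyl group, would raise the inhibition in this assay at all.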